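A Methyl Step Carried Across Two Related Cores

The compounds below may be only part of what the source reports. "The series", "measured", "known", "first", "only" and "open" are said of these compounds alone.

Compound 1 `COc1cc2c(Oc3ccc(NC(=O)c4cc(-c5ccccc5)ccn4)cc3F)ccnc2cc1OCCCN1CCCC1` and compound 2 `COc1cc2c(Oc3ccc(NC(=O)c4cc(-c5ccc(C)cc5)ccn4)cc3F)ccnc2cc1OCCCN1CCCC1` share one core, while compound 3 `COc1cc2c(Oc3ccc(NC(=O)c4nccc(-c5ccccc5)n4)cc3F)ccnc2cc1OCCCN1CCCCC1` and compound 4 `COc1cc2c(Oc3ccc(NC(=O)c4nccc(-c5ccc(C)cc5)n4)cc3F)ccnc2cc1OCCCN1CCCCC1` share a second. The difference between the two cores is not broken down here; compound 3 differs from compound 1 in more than one place.

In a functional assay on A549 cells (Homo sapiens) for cytotoxicity, read by MTT assay, with a stated time of 72 h (a higher number here means a weaker inhibitor, a lower number a stronger inhibitor), compound 1 gives 1580 nM. In this assay compound 2 gives 1060 nM. The change between them is methyl in place of hydrogen on an aromatic carbon, and the step it made was a 1.5-fold lower number from compound 1 to compound 2 (0.17 log units; within the scatter). Since the two values lie within the usual scatter, no order between compound 1 and compound 2 is claimed.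

The same change is made on the second core: compound 3 becomes compound 4 by methyl in place of hydrogen on an aromatic carbon, with the methyl entering at the same kind of place as before. For compound 3 the entry in this assay reads "not determined" (no result reported), so the second core has no measured starting point.

The expectation for compound 4 therefore rests on the first core alone. Because the matched step a 1.5-fold lower number from compound 1 to compound 2 (0.17 log units; within the scatter) stayed within the scatter, the change from compound 3 to compound 4 is expected to be similarly small, with the added uncertainty that compound 3 itself has no number. Compound 4 is expected to give about 1200 nM in this assay, with a plausible range from 300 nM to 5000 nM.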

Compound 4, half-maximal inhibitory concentration: 900 nM
Beside the measured number, compound 4's estimate is 1.3-fold (0.12 log units) above it; low and high end bracket the measured number.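

Going by these compounds alone, compound 3 has no single number in this assay and no step from compound 3 to compound 4 can be read, leaving compound 4 at 900 nM without a measured partner on its core. The compounds shown leave open whether the methyl change does the same on this core as on the core of compound 1. No evidence at hand bears on the result for compound 4.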